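Bromo in Place of Tert-Butyl on the Shared Core

The compounds below may be only part of what the source reports. "The series", "measured", "known", "first", "only" and "open" are said of these compounds alone.

Within the data shown here, in a functional assay on HeLa cells (Homo sapiens) (on this read-out higher numbers stand for weaker inhibition and lower numbers for stronger inhibition), compound 3 `CC(C)(C)c1ccc(C(=O)CC(SCC(=O)O)C(=O)O)cc1` gives 1390 nM, the lowest of the three numbers measured so far. Compound 1 `CCc1ccc(C(=O)CC(SCC(=O)O)C(=O)O)cc1` gives 4790 nM and compound 2 `CC(C)c1ccc(C(=O)CC(SCC(=O)O)C(=O)O)cc1` gives 3330 nM in this assay. The measured steps are a 1.4-fold lower number from compound 1 to compound 2 (0.16 log units; within the scatter), a 2.4-fold lower number from compound 2 to compound 3 (0.38 log units; beyond the scatter) and a 3.4-fold lower number from compound 1 to compound 3 (0.54 log units; beyond the scatter). Compound 4 `O=C(O)CSC(CC(=O)c1ccc(Br)cc1)C(=O)O` differs from compound 3 by bromo in place of tert-butyl on an aromatic carbon. Every measured step exchanged one alkyl group for another at this position, and none involved bromo, so they bear on the new step only indirectly. Those steps moved the number downward as ethyl gave way to isopropyl and then tert-butyl; the new change removes the tert-butyl that accompanied the lowest number, so the expectation is a modest step toward a higher number, held with wide uncertainty. One therefore expects compound 4 to give about 4000 nM, plausibly between 1500 nM and 12000 nM, which corresponds to an expected 2.9-fold higher number from compound 3 to compound 4 (0.46 log units; beyond the scatter).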

Compound 4, half-maximal inhibitory concentration: 9510 nM
Estimate against measurement, compound 4: 2.4-fold (0.38 log units) below; low and high end bracket the measured number.
By their numbers in this assay, from the lowest: compound 3; then compounds 2, 1 and 4 (each within the scatter of the next, the first and the last beyond it).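

In this assay, among these compounds, bromo is the first group at this position that is not an alkyl group, and exchanging tert-butyl for it gives a 6.8-fold higher number from compound 3 to compound 4 (0.84 log units; beyond the scatter) as the largest step seen so far. The exchange for isopropyl likewise gives a 2.9-fold higher number from compound 2 to compound 4 (0.46 log units; beyond the scatter) beyond the scatter, while a 2.0-fold higher number from compound 1 to compound 4 (0.30 log units; within the scatter) is within the scatter, so bromo and ethyl cannot be told apart here. Nothing measured on these compounds accounts for these steps.

The compounds shown leave open whether other halogens, such as chloro or iodo, would give numbers close to that of bromo. They also leave open where a methoxy group, an amine or a longer chain such as n-butyl would fall relative to compound 3 and compound 4.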